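The source may hold more compounds than are shown below. What is called first, only, known or untested is meant among the compounds shown, and "the series" means these compounds.

In a functional assay on blood (Homo sapiens), with a stated time of 60 min, in the presence of a further agent that is not named here (a lower number here means that less compound is needed, a higher number that more compound is needed for the effect), compound 1 (`CON(C)C(=O)C1(S(=O)(=O)c2ccc(Oc3ccc(OC(F)(F)F)cc3)cc2)CCC2(CCNCC2)C1`) gives 3700 nM. Compound 2 (`O=S(=O)(c1ccc(Oc2ccc(OC(F)(F)F)cc2)cc1)C1CCC2(CCNCC2)C1`) reads > 15000 nM, which is a limit. Compound 3 (`COC(=O)C1(S(=O)(=O)c2ccc(Oc3ccc(OC(F)(F)F)cc3)cc2)CCC2(CCNCC2)C1`) also reads only a limit, > 15000 nM, so it stands at the limit of > 15000 nM in this assay, at which 2 of the 3 values shown sit.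

Compound 4 (`O=C(OCc1ccccc1)C1(S(=O)(=O)c2ccc(Oc3ccc(OC(F)(F)F)cc3)cc2)CCC2(CCNCC2)C1`) extends the methoxycarbonyl of compound 3 to benzyloxycarbonyl: phenyl in place of hydrogen on a saturated chain carbon bound to an oxygen next to a carbonyl group. The nearest measured change is an at least 4.0-fold higher number from compound 1 to compound 3 (0.60 log units; beyond the scatter), which replaces the whole group on the carbonyl rather than the methyl. an at least 4.0-fold higher number from compound 1 to compound 2 (0.60 log units; beyond the scatter) shows the loss of that group, while a step that the two limits leave unreadable from compound 2 to compound 3 gives no size. Among the measured compounds shown here, no measured step covers this exact change, so no step beyond the scatter is expected in this assay. The expected step is a number no higher from compound 3 to compound 4 (the limit leaves the size open). For compound 4 the estimate is 15000 nM, with an expected range of 5000 nM to 30000 nM.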

Compound 4, half-maximal effective concentration: > 15000 nM
Compound 4 gave a limit, no number; the forecaster's own chance of this, stated with the estimate: 60%; the middle value lies on the limit itself.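

Enlarging the ester from methoxycarbonyl to benzyloxycarbonyl brings no measurable return of activity; the steps from compound 3 to compound 4 and from compound 2 to compound 4 cannot be read, as both ends of each are limits. Benzyloxy on the carbonyl carbon, like methoxy, falls short of the group in compound 1, with an at least 4.0-fold higher number from compound 1 to compound 4 (0.60 log units; beyond the scatter). Compound 4 adds a further limit to the series: the limit of > 15000 nM in this assay, at which 3 of the 4 values shown sit.

As far as these compounds go, whether a dimethylamino group or the hydroxy group of a carboxylic acid on the carbonyl carbon would give a number stays open. From the compounds shown here alone, how far compound 2, compound 3 and compound 4 lie from one another also stays open.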